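Branching the Ketone Chain: From Compound 3 to Compound 4

The source may hold more compounds than are shown below. What is called first, only, known or untested is meant among the compounds shown, and "the series" means these compounds.

Compound 1, `Cc1c(OCCCCOCOc2ccc(C(=O)O)cc2)ccc(C(=O)CC2CCCC2)c1O`: 95.4%
Compound 2, `CCC(=O)c1ccc(OCCCCOc2cc(C(=O)O)ccc2OC)c(C)c1O`: 72.6%
Compound 3, `CCCC(=O)c1ccc(OCCCCOc2cc(C(=O)O)ccc2OC)c(C)c1O`: 82.8%

In an assay on HEK293 cells for positive allosteric modulation of metabotropic glutamate receptor 2 (Rattus norvegicus), read by thallium flux, with a stated time of 2.5 min (on this read-out higher numbers stand for larger maximal responses and lower numbers for smaller maximal responses), compound 3 stands second highest of the three measured numbers: compound 2 lies below it and compound 1 above it, both gaps beyond the scatter. Compound 4, `COc1ccc(C(=O)O)cc1OCCCCOc1ccc(C(=O)C(C)C)c(O)c1C`, differs from compound 3 by isopropyl in place of propyl on a carbonyl carbon. Among the compounds with values here, the only measured step that bears on this is a number 10.2 percentage points higher from compound 2 to compound 3 (beyond the scatter), a different alteration of the same chain; no measured pair shows a branched chain against a straight one. With such a loose precedent, no step beyond the scatter is expected. Compound 4 is therefore estimated at 80%, within a range of 62% to 95%. The implied step, a number 2.8 percentage points lower from compound 3 to compound 4 (within the scatter), is expected to stay within the scatter.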

Compound 4, largest response reached (reported as percent of maximum), in percent of the reference or control that the assay uses: 66.6%
Compound 4: the middle estimate sits 13.4 percentage points above what was measured; measured number inside the range.
By their numbers in this assay, from the lowest: compounds 4 and 2 (each within the scatter of the next); then compound 3; then compound 1.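

In this assay, the same three carbons joined differently do not read alike: isopropyl in place of propyl on a carbonyl carbon lowers the response (a number 16.2 percentage points lower from compound 3 to compound 4 (beyond the scatter)). Methyl on the chain carbon bound to the carbonyl carbon stays within the scatter (a number 6 percentage points lower from compound 2 to compound 4 (within the scatter)), whereas methyl two bonds along the chain from the carbonyl carbon goes beyond it (a number 10.2 percentage points higher from compound 2 to compound 3 (beyond the scatter)), so where the added carbon sits on this chain matters. From the compounds shown here alone, how a cyclopropyl or a tert-butyl on the carbonyl carbon would read remains open. Nothing measured here explains the difference.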